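Putting 4-Aminophenyl in Place of 2-Chlorophenyl

A few compounds are considered here, and "the series" means these few. Any claim that something is new, unique, unknown or untested is made for them only; others in the source may bear on it.

In a functional assay on MCF7 cells (Homo sapiens) for cytotoxicity, read by MTT assay, with a stated time of 96 h (on this read-out lower numbers stand for stronger inhibition and higher numbers for weaker inhibition), compound 1 `COc1cc(C(=O)c2cn(-c3cccc(N)c3)cc2-c2ccc(N)cc2)cc(OC)c1OC` gives 14 nM and compound 2 `COc1cc(C(=O)c2cn(-c3ccc(N)cc3)cc2-c2ccccc2Cl)cc(OC)c1OC` gives 83 nM, the higher of the two numbers, with a gap beyond the scatter. Compound 3 `COc1cc(C(=O)c2cn(-c3ccc(N)cc3)cc2-c2ccc(N)cc2)cc(OC)c1OC` has 4-aminophenyl in place of the 2-chlorophenyl of compound 2 on an aromatic carbon (4-aminophenyl in place of 2-chlorophenyl on an aromatic carbon). Within the data shown here, no measured pair shows this change alone, so the expectation rests on compound 1, which also carries 4-aminophenyl and gives 14 nM. A step to a lower number, beyond the scatter, is expected in this assay, with an estimated 3.3-fold lower number from compound 2 to compound 3 (0.52 log units; beyond the scatter). Compound 3 is expected at 25 nM, within an estimated range of 7 nM to 90 nM.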

Compound 3, half-maximal inhibitory concentration: 15 nM
Compound 3: middle estimate off by 1.7-fold (0.22 log units), on the high side, and the stated range covers the measured number.
By their numbers in this assay, from the lowest: compounds 1 and 3 (each within the scatter of the next); then compound 2.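

In this assay, among these compounds, the change from 2-chlorophenyl to 4-aminophenyl on the aromatic carbon, read alone for the first time, gives a 5.5-fold lower number from compound 2 to compound 3 (0.74 log units; beyond the scatter) and so counts at this position. Moving the amine on the phenyl of the aromatic nitrogen gives a 1.1-fold higher number from compound 1 to compound 3 (0.03 log units; within the scatter) and shows no difference there. Nothing measured here accounts for either step.

As far as these compounds go, what a plain phenyl, a 4-chlorophenyl or a 4-hydroxyphenyl would give at this carbon stays open, so the step cannot yet be divided between the entering amine and the leaving chlorine.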